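The source may report more compounds than this note shows. Statements on the series, on what has been measured and on what is new or still open speak of the compounds shown alone.

For the measured compounds named here, compound 1 `Cc1c(C(=O)/C=C/c2ccc(Cl)cc2)[n+]([O-])c2ccccc2[n+]1[O-]` gives 7750 nM in a functional assay on MOLT-4 cells (Homo sapiens) for inhibition, with a stated time of 3 days (a higher number here means a weaker inhibitor, a lower number a stronger inhibitor), and stands at one end of the two numbers measured so far, but compound 2 `COc1cc(/C=C/C(=O)c2c(C)[n+]([O-])c3ccccc3[n+]2[O-])cc(OC)c1OC`, which gives 5510 nM in this assay, lies within the scatter of it. Compound 3 `Cc1ccc(/C=C/C(=O)c2c(C)[n+]([O-])c3ccccc3[n+]2[O-])cc1` is compound 1 with methyl in place of chloro on an aromatic carbon. Going by the values given here, no pair of measured compounds differing in one place is available to calibrate such a change. In this assay the expected step is a 1.0-fold lower number from compound 1 to compound 3 (0.01 log units; within the scatter), nothing beyond the scatter in either direction. Compound 3 is therefore estimated at 7500 nM in this assay, with a range from 3000 nM to 19000 nM.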

Compound 3, half-maximal inhibitory concentration: 8400 nM
Compound 3: the middle estimate sits 1.1-fold (0.05 log units) below what was measured, within the range that was stated.
By their numbers in this assay, from the lowest: compounds 2, 1 and 3 (each within the scatter of the next).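

For the compounds shown here, on the aromatic carbon para to a large group, methyl in place of chloro gives a step within the scatter in this assay (a 1.1-fold higher number from compound 1 to compound 3 (0.03 log units; within the scatter)), now the only calibrated change. In this assay, 4-chlorophenyl and 4-methylphenyl therefore cannot be told apart at this position. No available evidence bears on this result.

From the compounds shown here alone, whether an amine, a hydroxyl or a carboxylic acid at this position would move the number beyond the scatter remains open. So does the effect of any change to the shared core.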